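This account rests on a few compounds, and the source may have more. Where it says the series, first, only, none or still open, it means among the compounds named here.

Working notes on the series. In a functional assay on HUVEC cells (Homo sapiens) for inhibition, read by ELISA (on this read-out lower numbers stand for stronger inhibition and higher numbers for weaker inhibition), compound 1 `[O-][S+](Cc1ccccc1)c1nnc(-c2ccncc2)o1` gives 3000 nM, compound 2 `[O-][S+](Cc1ccccc1)c1nnc(-c2cccnc2)o1` gives 6000 nM and compound 3 `[O-][S+](Cc1ccccc1)c1nnc(-c2ccccn2)o1` gives 4000 nM. Compound 3 stands inside this narrow band of numbers, separated from neither of the others.

The next structure is compound 4 `[O-][S+](Cc1ccccc1)c1nnc(-c2cccs2)o1`, with thiophen-2-yl in place of pyridin-2-yl on an aromatic carbon. For the measured compounds named here, the only measured steps at this place exchange pyridin-2-yl, pyridin-3-yl and pyridin-4-yl for one another: a 2.0-fold higher number from compound 1 to compound 2 (0.30 log units; within the scatter), a 1.3-fold higher number from compound 1 to compound 3 (0.12 log units; within the scatter) and a 1.5-fold lower number from compound 2 to compound 3 (0.18 log units; within the scatter). All three stay within the scatter. None of them introduces thiophen-2-yl, so they bear on this change only indirectly, and the range has to stay wide.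

On these small steps, no shift beyond the scatter is expected in this assay, and no direction can be assigned. The estimated change is no change at the digits printed from compound 3 to compound 4 (within the scatter). Compound 4 is expected at about 4000 nM, with an estimated range of 1500 nM to 10000 nM.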

Compound 4, half-maximal inhibitory concentration: 6000 nM
Estimate against measurement, compound 4: 1.5-fold (0.18 log units) below; the measured number falls inside the stated range.
By their numbers in this assay, from the lowest: compounds 1, 3, 2 and 4 (each within the scatter of the next).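

Thiophen-2-yl puts a five-membered aromatic ring with sulfur as its hetero atom at this place on the shared core, whereas the earlier compounds only exchanged pyridin-2-yl, pyridin-3-yl and pyridin-4-yl for one another. In this assay this change gives a 1.5-fold higher number from compound 3 to compound 4 (0.18 log units; within the scatter), no change at the digits printed from compound 2 to compound 4 (within the scatter) and a 2.0-fold higher number from compound 1 to compound 4 (0.30 log units; within the scatter), and all three steps lie within the scatter. Across compound 1, compound 2, compound 3 and compound 4, therefore, neither the change of ring size nor the loss of the ring nitrogen separates the numbers.

As far as these compounds go, whether an amine, a carboxylic acid or a longer alkyl chain at this place would move the number beyond the scatter remains open. No supporting data are available to explain why these numbers stay together.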